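The compounds below may be only part of what the source reports. "The series", "measured", "known", "first", "only" and "open" are said of these compounds alone.

Measured so far:
compound 1 `CN(C)/C=N/N=C/c1cn(S(=O)(=O)c2ccc(I)cc2)c2cccc([N+](=O)[O-])c12` gives 6340 nM in a functional assay on HEK293 cells for inhibition of 5-hydroxytryptamine receptor 6 (Homo sapiens), read by calcium flux and cAMP accumulation, with a stated time of 10 min; a higher number here means a weaker inhibitor, a lower number a stronger inhibitor;
compound 2 `COc1ccc(S(=O)(=O)n2cc(/C=N/N=C/N(C)C)c3c([N+](=O)[O-])cccc32)cc1` gives 740 nM in this assay.

Of the two measured compounds, compound 2 has the lower number in this assay, and its nearest neighbour is compound 1, separated by an 8.6-fold lower number from compound 1 to compound 2 (0.93 log units; beyond the scatter). For the measured compounds named here, that single step, methoxy in place of iodo on an aromatic carbon, is the only measured change on this aryl group.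

Compound 3 `COc1ccc(Cl)cc1S(=O)(=O)n1cc(/C=N/N=C/N(C)C)c2c([N+](=O)[O-])cccc21` differs from compound 2 by 5-chloro-2-methoxyphenyl in place of 4-methoxyphenyl on a sulfonyl sulfur. Going by the values given here, no measured step here moves the methoxy to a different position or adds a chlorine, so the one recorded step bears on it only loosely: it shows that swapping a substituent on this ring can shift the number beyond the scatter, without saying in which direction this particular change would go. A step of modest size is therefore expected, with a wider uncertainty than usual.

For compound 3 the estimated value in this assay is 1000 nM, with a likely range from 200 nM to 5000 nM, corresponding to an expected step of a 1.4-fold higher number from compound 2 to compound 3 (0.13 log units; within the scatter).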

Compound 3, half-maximal inhibitory concentration: 2440 nM
Compound 3: the middle estimate sits 2.4-fold (0.39 log units) below what was measured, and the stated range covers the measured number.
By their numbers in this assay, from the lowest: compound 2; then compound 3; then compound 1.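

The aryl group on the sulfonyl sulfur now has three measured versions, and in this assay the change to 5-chloro-2-methoxyphenyl gives a 3.3-fold higher number from compound 2 to compound 3 (0.52 log units; beyond the scatter), so this group gives up part of what 4-methoxyphenyl gained. Part of that gain remains relative to 4-iodophenyl, with a 2.6-fold lower number from compound 1 to compound 3 (0.41 log units; beyond the scatter), which places compound 3 in the middle of the three. No supporting data are available to explain this shift.

Compound 3 differs from compound 2 in two ways within one group, with a chlorine added and the methoxy placed differently, so the compounds shown leave open which of these accounts for the step. Also open, on these data alone, is how the number would respond to an amine or a carboxylic acid on this aryl ring, or to a longer chain in place of the methoxy.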